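The compounds below may be only part of what the source reports. "The series", "measured", "known", "first", "only" and "open" are said of these compounds alone.

Working notes on the series. Compound 1 `FC(F)(F)c1ccc(-c2ccc(-c3ccc(-c4nc5ccccc5[nH]4)cc3)cc2)cc1` in a functional assay on PC-3 cells (Homo sapiens) for inhibition, read by sulforhodamine B assay (on this read-out higher numbers stand for weaker inhibition of growth and lower numbers for stronger inhibition of growth), gives 45200 nM. Compound 2 `FC(F)(F)Oc1ccc(-c2ccc(-c3ccc(-c4nc5ccccc5[nH]4)cc3)cc2)cc1` in this assay gives 100000 nM, and the step of a 2.2-fold higher number from compound 1 to compound 2 (0.34 log units; beyond the scatter) goes with the change (trifluoromethoxy in place of trifluoromethyl on an aromatic carbon). Compound 3 `Cc1ccc2[nH]c(-c3ccc(-c4ccc(-c5ccc(C(F)(F)F)cc5)cc4)cc3)nc2c1` carries the change methyl in place of hydrogen on an aromatic carbon on the core of compound 1; in this assay compound 3 gives 2010 nM; the step is a 22-fold lower number from compound 1 to compound 3 (1.35 log units; beyond the scatter), the largest in the set.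

Compound 4 `Cc1ccc2[nH]c(-c3ccc(-c4ccc(-c5ccc(OC(F)(F)F)cc5)cc4)cc3)nc2c1` is not yet measured. It differs from compound 3 by trifluoromethoxy in place of trifluoromethyl on an aromatic carbon. This is the same change as from compound 1 to compound 2, and the surroundings of the place are described in the same words in both cases; what differs between the two pairs is the core, by methyl in place of hydrogen on an aromatic carbon.

Among the measured compounds shown here, for compound 4 a step of about a 2.2-fold higher number from compound 3 to compound 4 (0.34 log units; beyond the scatter) in this assay is expected, of the same size as the earlier one, because a 2.2-fold higher number from compound 1 to compound 2 (0.34 log units; beyond the scatter) is the only measured instance of this change; the two pairs share the place but only one observation is available. Compound 4 is thus estimated at 4400 nM in this assay, between 1800 nM and 11000 nM.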

Compound 4, concentration for 50% growth inhibition: 2010 nM
Estimate against measurement, compound 4: 2.2-fold (0.34 log units) above, within the range that was stated.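

Trifluoromethoxy in place of trifluoromethyl gives no change at the digits printed from compound 3 to compound 4 (within the scatter) in this assay, and set beside the same change on the core of compound 1, the two steps do not differ: the same change on two cores in this assay, a 2.2-fold higher number (0.34 log units; beyond the scatter) from compound 1 to compound 2 and no change at the digits printed (within the scatter) from compound 3 to compound 4, 2.2-fold (0.34 log units) apart, within the scatter of two such steps. Methyl in place of hydrogen, now read with trifluoromethoxy in the molecule, gives a 50-fold lower number from compound 2 to compound 4 (1.70 log units; beyond the scatter), and this step also agrees with its earlier counterpart: the same change on two cores in this assay, a 22-fold lower number (1.35 log units; beyond the scatter) from compound 1 to compound 3 and a 50-fold lower number (1.70 log units; beyond the scatter) from compound 2 to compound 4, 2.2-fold (0.34 log units) apart, within the scatter of two such steps. Across these four compounds, each change therefore carries over from one core to the other within the scatter, but each comparison rests on just two pairs, so this does not show that either step would hold on a further core, nor does it give any reason for the size of either step.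

Still open, from the compounds shown here alone, is whether another group in place of the methyl, such as a methoxy, an amine or a carboxylic acid, would give a step of similar size. Also open, going by these compounds, is whether a longer chain in place of trifluoromethyl would follow the same course on both cores.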